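This account rests on a few compounds, and the source may have more. Where it says the series, first, only, none or still open, it means among the compounds named here.

Measured so far in a functional assay on PC-3 cells (Homo sapiens) for cytotoxicity, read by MTT assay, with a stated time of 48 h; on this read-out lower numbers stand for stronger inhibition and higher numbers for weaker inhibition:
compound 1 `COc1ccc(/C=C/C(=O)/C=C/c2cc3ccccc3nc2Cl)cc1`, > 10000 nM
compound 2 `COc1ccc(/C=C/C(=O)/C=C/c2cc3ccccc3nc2Cl)c(OC)c1`, > 10000 nM
compound 3 `COc1ccc(/C=C/C(=O)/C=C/c2cc3ccccc3nc2Oc2cccc(Cl)c2)cc1OC`, > 10000 nM

Each of these values is a limit of the assay rather than a number. Compound 1 gives only the limit > 10000 nM in this assay. Compound 2 likewise gives only the limit > 10000 nM. Compound 3 also stays at the limit > 10000 nM. The change from compound 1 to compound 2 is methoxy in place of hydrogen on an aromatic carbon, and its step, a step that the two limits leave unreadable from compound 1 to compound 2, cannot be read because of the limit of > 10000 nM in this assay, at which 3 of the 3 values shown sit. The difference between the cores of compound 1 and compound 3 is not broken down here.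

Compound 4 `COc1cc(OC)c(OC)cc1/C=C/C(=O)/C=C/c1cc2ccccc2nc1Oc1cccc(Cl)c1` is not yet measured. It differs from compound 3 by methoxy in place of hydrogen on an aromatic carbon, the same kind of change as from compound 1 to compound 2, though here the place is also para to a methoxy group. Since compound 3 sits at the limit > 10000 nM and the earlier step was unreadable, compound 4 is expected to stay near that limit, the estimated step being a step that the limit leaves unreadable from compound 3 to compound 4. Compound 4 is therefore estimated at 15000 nM, between 7000 nM and 40000 nM.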

Compound 4, half-maximal inhibitory concentration: > 10000 nM
Compound 4 gave a limit, no number; the forecaster's own chance of this, stated with the estimate: 75%; the middle value is on the limit's open side.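

No step can be read between compound 3 and compound 4, as both give only a limit: the limit of > 10000 nM in this assay, at which 4 of the 4 values shown sit. In this assay the compounds shown leave open whether methoxy in place of hydrogen changes potency at all.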